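The source may hold more compounds than are shown below. What is called first, only, known or untested is meant among the compounds shown, and "the series" means these compounds.

Among the measured compounds shown here, in an ADME assay on CHO cells (Cricetulus griseus) for cytotoxicity, read by MTT assay (on this read-out higher numbers stand for lower toxicity in this test and lower numbers for higher toxicity in this test), compound 2 `O=C(c1ccnc(Nc2nc3cnc(Nc4ccc(F)c(F)c4)cc3[nH]2)c1)N1CCC(F)(F)CC1` gives 29000 nM as the only exact number so far. Compound 1 `C[C@@H]1CN(C(=O)c2ccnc(Nc3nc4cnc(Nc5ccc(F)c(F)c5)cc4[nH]3)c2)C[C@H](C)O1` reads > 50000 nM and that is a limit of the assay, not a number. For the measured compounds named here, the one measured step is an at least 1.7-fold lower number from compound 1 to compound 2 (0.23 log units; that floor lies within the scatter) on a carbonyl carbon, and its floor lies within the scatter. Compound 3 `O=C(c1ccnc(Nc2nc3cnc(NC4CCC(F)(F)CC4)cc3[nH]2)c1)N1CCC(F)(F)CC1` differs at another place, with 4,4-difluorocyclohexyl in place of 3,4-difluorophenyl on a nitrogen on an aromatic ring putting 4,4-difluorocyclohexyl in place of 3,4-difluorophenyl on a nitrogen on an aromatic ring. Going by the values given here, no measured step covers that place, so nothing beyond the scatter is expected, with a 1.2-fold higher number from compound 2 to compound 3 (0.08 log units; within the scatter) as the estimated step. In this assay compound 3 is expected at 35000 nM with an estimated range from 15000 nM to 80000 nM as its bounds.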

Compound 3, half-maximal cytotoxic concentration: > 50000 nM
Compound 3 gave a limit, no number (the forecaster's own chance of this, stated with the estimate: 35%); at least 1.4-fold (0.15 log units) between middle value and limit.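

Until now, the place on a nitrogen on an aromatic ring had carried only 3,4-difluorophenyl. Compound 3 shows that 4,4-difluorocyclohexyl, with its non-aromatic ring, gives no sign of a lower number in this assay: the result is an at least 1.7-fold higher number from compound 2 to compound 3 (0.23 log units; that floor lies within the scatter). The true size of this step cannot be read, because compound 3 gives a limit rather than a number: the limit of > 50000 nM in this assay, at which 2 of the 3 values shown sit.

Going by these compounds, whether plain cyclohexyl without fluorine, a longer chain or a ring carrying an amine at this nitrogen would give a lower number remains open.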